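The compounds below may be only part of what the source reports. "The series", "measured", "known", "first", "only" and "open" are said of these compounds alone.

Working notes on the prostacyclin series.

Three compounds of the shared core have numbers in an assay for displacement of a labelled ligand from prostacyclin receptor (Homo sapiens); on this read-out lower numbers stand for stronger inhibition and higher numbers for weaker inhibition. Compound 1 `O=C(O)COc1cccc2c1CCC(C/C=C/CC(c1ccccc1)c1ccccc1)C2` gives 3100 nM. Compound 2 `O=C(O)COc1cccc2c1CCC(C/C=C/C(O)Cc1ccccc1)C2` gives 4900 nM. Compound 3 `CCCCCC(O)/C=C/CC1CCc2c(cccc2OCC(=O)O)C1` gives 7800 nM, the highest of the three; the gap to compound 2 is within the scatter, and the gap to compound 1 is beyond it, compound 1 having the lower number.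

One step among the measured compounds is a single change: a 1.6-fold higher number from compound 2 to compound 3 (0.20 log units; within the scatter), which is within the scatter, so exchanging butyl for phenyl at that chain carbon made no real difference.

Compound 4 `O=C(O)COc1cccc2c1CCC(C/C=C/CCc1ccccc1)C2` is not yet measured. The change from compound 3 is phenethyl in place of 1-hydroxyhexyl on a double-bonded chain carbon bound to a double-bonded chain carbon. Among the measured compounds shown here, no measured step covers removal of the hydroxyl alone; the closest bearing comes from compound 1, which carries two phenyl groups and no hydroxyl and sits beyond the scatter below compound 3, and from compound 2, where a hydroxyl is present beside a single phenyl. On that basis a modest move toward lower numbers in this assay is expected for compound 4, roughly a 2.0-fold lower number from compound 3 to compound 4 (0.29 log units; within the scatter), with wide uncertainty. The estimate for compound 4 is 4000 nM, with a range of 1500 nM to 10000 nM.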

Compound 4, half-maximal inhibitory concentration: 5300 nM
Beside the measured number, compound 4's estimate is 1.3-fold (0.12 log units) below it; measured number inside the range.
By their numbers in this assay, from the lowest: compounds 1, 2, 4 and 3 (each within the scatter of the next, the first and the last beyond it).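

The hydroxy group on the saturated chain carbon now has a single-change step of its own in this assay: hydrogen in its place gives (a 1.1-fold higher number from compound 2 to compound 4 (0.03 log units; within the scatter)), so that change made no real difference here. Hydrogen in place of phenyl on the saturated chain carbon gives (a 1.7-fold higher number from compound 1 to compound 4 (0.23 log units; within the scatter)), and phenethyl in place of 1-hydroxyhexyl on the double-bonded chain carbon gives (a 1.5-fold lower number from compound 3 to compound 4 (0.17 log units; within the scatter)), so neither the extra phenyl of compound 1 nor the exchange of the whole chain end moves the number beyond the scatter. All three single changes at this end of the chain are therefore indistinguishable in this read-out, and nothing at hand says why these changes leave the number so little altered.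

Still open, on these data alone, is whether a chain end of another kind, such as an amine, a carboxylic acid or a longer chain ending in a phenyl group, would produce a step beyond the scatter. The compounds shown also leave open what a change at the oxyacetic acid group on the shared core, or a saturated chain in place of the double bond, would do to the number.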